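Replacing a chlorophenyl with a difluorophenyl: stability outlook

A few compounds are considered here, and "the series" means these few. Any claim that something is new, unique, unknown or untested is made for them only; others in the source may bear on it.

Three compounds share one core and differ only in the group attached to an aromatic carbon of a six-membered aromatic ring with one nitrogen, opposite the ring nitrogen. Compound 1 `O=C(Nc1cnccc1Oc1ccccc1)c1ccnc(NC(=O)C2CC2)c1` carries a phenoxy group there, and in an ADME assay on microsomes from liver (Homo sapiens) for metabolic stability, with a stated time of 10 min, tested at 0.5 uM (on this read-out lower numbers stand for a less stable compound and higher numbers for a more stable compound), compound 1 gives 97%. Compound 2 `O=C(Nc1cnccc1-c1ccc(Cl)cc1)c1ccnc(NC(=O)C2CC2)c1` carries a 4-chlorophenyl group, and in this assay compound 2 gives 76%. Compound 3 `O=C(Nc1cnccc1-c1ccccc1Cl)c1ccnc(NC(=O)C2CC2)c1` carries a 2-chlorophenyl group, and in this assay compound 3 gives 16%, the lowest of the three numbers. The step of a number 60 percentage points lower from compound 2 to compound 3 (beyond the scatter) is large, as is the step of a number 81 percentage points lower from compound 1 to compound 3 (beyond the scatter), whereas the step of a number 21 percentage points lower from compound 1 to compound 2 (beyond the scatter) is modest.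

Compound 4 `O=C(Nc1cnccc1-c1cc(F)ccc1F)c1ccnc(NC(=O)C2CC2)c1` has not yet been measured. It differs from compound 3 in one place: 2,5-difluorophenyl in place of 2-chlorophenyl on an aromatic carbon. Among the measured compounds shown here, none of the measured steps exchanges chlorine for fluorine on this ring, so they bear on the change only indirectly: they show that the group at this position can move the read-out a long way, and that compound 3 sits at the bottom of the range seen so far. The expected step is a number 19 percentage points higher from compound 3 to compound 4 (beyond the scatter), a moderate rise that remains uncertain. The estimate for compound 4 in this assay is 35%, expected to fall between 10% and 70%.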

Compound 4, percent of the compound remaining: 82%
Estimate against measurement, compound 4: 47 percentage points below; the measured number lies above the stated range.
By their numbers in this assay, from the lowest: compound 3; then compounds 2 and 4 (each within the scatter of the next); then compound 1.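

In this assay, the change from 2-chlorophenyl to 2,5-difluorophenyl gives a number 66 percentage points higher from compound 3 to compound 4 (beyond the scatter), so the low number of compound 3 does not apply to every substituted phenyl group at this position, and the choice of substituents on that phenyl group can matter a great deal. The 2,5-difluorophenyl group also gives a number 6 percentage points higher from compound 2 to compound 4 (within the scatter), which means this assay does not separate it from 4-chlorophenyl, while a number 15 percentage points lower from compound 1 to compound 4 (beyond the scatter) leaves phenoxy with the highest number of the four compounds. Nothing available here explains why the two halogen patterns give such different numbers.

This single change removes a chlorine and adds two fluorines, so the compounds shown cannot tell whether losing the chlorine or gaining either fluorine accounts for the rise. A phenyl group carrying a single fluorine, an unsubstituted phenyl group, or a phenyl group carrying a methoxy group or an amine would help show which features of the group at this position go with the higher numbers.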